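The source may hold more compounds than are shown below. What is called first, only, known or untested is meant among the compounds shown, and "the series" means these compounds.

Compound 3 `CCCCCc1ccc(C#Cc2c(-c3ccc(CCCCC)cc3)oc3nc(=O)n(Cc4cn(Cc5ccccc5)nn4)cc23)cc1` carries a benzyl group on the nitrogen of its five-membered ring with three nitrogens. In a functional assay on HeLa cells (Homo sapiens) for antiproliferative activity, read by MTT assay, with a stated time of 72 h (on this read-out higher numbers stand for weaker inhibition and lower numbers for stronger inhibition), compound 3 gives 73000 nM, which is the higher of the two numbers shown, while the nearest neighbour, compound 1 `O=c1nc2oc(CCCCl)c(C#CCCCCCl)c2cn1Cc1cn(-c2ccc(F)cc2)nn1`, gives 41800 nM, a gap that stays within the usual scatter of this assay. Compound 2 `O=c1nc2oc(CCCCl)c(C#CCCCCl)c2cn1Cc1cn(-c2ccc(Cl)cc2)nn1` gives only a limit in this assay, > 100000 nM, so no number is known for it. Compound 4 `CCCCCc1ccc(C#Cc2c(-c3ccc(CCCCC)cc3)oc3nc(=O)n(Cc4cn(-c5ccc(Cl)cc5)nn4)cc23)cc1` is the partner of compound 3 in which (4-chlorophenyl in place of benzyl on an aromatic nitrogen). Within the data shown here, no pair of measured compounds differs in this one place alone, so the step cannot be read from the data. All three measured compounds sit in the weak range, and the change is expected to leave compound 4 there as well, with an expected step of a 1.2-fold higher number from compound 3 to compound 4 (0.09 log units; within the scatter) from compound 3 to compound 4 that does not clearly exceed the scatter. The expected value for compound 4 in this assay is 90000 nM, within a range from 35000 nM to 250000 nM.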

Compound 4, half-maximal inhibitory concentration: > 100000 nM
Compound 4: only a limit was reported; the forecaster's own chance of this, stated with the estimate: 40%; middle value at least 1.1-fold (0.04 log units) away from the limit.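

Among these compounds, this is the first pair of compounds that differ only in the group on the aromatic nitrogen of the five-membered ring: in this assay, 4-chlorophenyl in place of benzyl gives an at least 1.3-fold higher number from compound 3 to compound 4 (0.13 log units; that floor lies within the scatter). The entry for compound 4, > 100000 nM, is a limit and not a number, so the step has only a floor, and that floor does not show a real loss of activity. This pair meets the same ceiling of the read-out as another compound shown: the limit of > 100000 nM in this assay, at which 2 of the 4 values shown sit.

The compounds shown leave open whether the chlorine or the swap from benzyl to a ring bonded directly to the nitrogen matters more. A plain phenyl or a 4-chlorobenzyl group at this position on the same core would separate the two, and a morpholine-bearing chain would test a quite different kind of group there.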